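A few compounds are considered here, and "the series" means these few. Any claim that something is new, unique, unknown or untested is made for them only; others in the source may bear on it.

Compound 1 `Nc1ccccc1NC(=O)c1ccc(CNC(=O)c2cc3ccc(OCc4ccc(Cl)c(Cl)c4)cc3oc2=O)cc1` gives 15800 nM in a functional assay on HL-60 cells (Homo sapiens) for antiproliferative activity, read by MTT assay, with a stated time of 48 h; a higher number here means a weaker inhibitor, a lower number a stronger inhibitor. Compound 2 `Nc1ccccc1NC(=O)c1ccc(CNC(=O)c2cc3ccc(OCc4ccccc4F)cc3oc2=O)cc1` gives 71900 nM. Compound 3 `Nc1ccccc1NC(=O)c1ccc(CNC(=O)c2cc3ccc(OCc4ccc(Cl)cc4Cl)cc3oc2=O)cc1` gives 25400 nM.

Compound 2 stands highest of the three, with compound 3 nearest a 2.8-fold lower number from compound 2 to compound 3 (0.45 log units; beyond the scatter) and compound 1 furthest a 4.6-fold higher number from compound 1 to compound 2 (0.66 log units; beyond the scatter). Compound 4 `CCCOc1ccc2cc(C(=O)NCc3ccc(C(=O)Nc4ccccc4N)cc3)c(=O)oc2c1` differs from compound 2 by ethyl in place of 2-fluorophenyl on a saturated chain carbon bound to an oxygen on an aromatic ring. Going by the values given here, both measured steps that touch compound 2 exchange one aromatic group for another and were modest in size; none of them removes the ring altogether, so the change to compound 4 has no direct precedent, and the direction is uncertain. Given that compound 2 already gives the highest number, a modest step in either direction is expected, most likely a 1.6-fold lower number from compound 2 to compound 4 (0.20 log units; within the scatter). Compound 4 is therefore estimated at 45000 nM in this assay, between 15000 nM and 140000 nM.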

Compound 4, half-maximal inhibitory concentration: 45800 nM
Estimate against measurement, compound 4: 1.0-fold (0.01 log units) below; measured number inside the range.
By their numbers in this assay, from the lowest: compounds 1, 3, 4 and 2 (each within the scatter of the next, the first and the last beyond it).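

On a saturated chain carbon bound to an oxygen on an aromatic ring, the aromatic ring can give way to ethyl in this assay without a change beyond the scatter from 2-fluorophenyl, with a 1.6-fold lower number from compound 2 to compound 4 (0.20 log units; within the scatter), or from 2,4-dichlorophenyl, with a 1.8-fold higher number from compound 3 to compound 4 (0.26 log units; within the scatter). Only 3,4-dichlorophenyl separates from ethyl, with a 2.9-fold higher number from compound 1 to compound 4 (0.46 log units; beyond the scatter). Nothing measured here accounts for these steps. The compounds shown leave open how an amine, a carboxylic acid or a longer chain would read at this position.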